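The source may report more compounds than this note shows. Statements on the series, on what has been measured and on what is new or still open speak of the compounds shown alone.

Measured so far in an ADME assay on HEL cells (Homo sapiens) for cytotoxicity, with a stated time of 3 days; on this read-out higher numbers stand for lower toxicity in this test and lower numbers for higher toxicity in this test:
- compound 1 `CCC1(Cc2ccccc2)OS(=O)(=O)C=C1OC`, where compound 1 gives > 200000 nM, which is a limit of the assay and not a number
- compound 2 `CCC1(Cc2ccccc2)OS(=O)(=O)C=C1OCCc1ccccc1`, where compound 2 gives 48000 nM

Compound 2 thus holds the only number shown in this assay; the other value is a limit, as the limit of > 200000 nM in this assay, at which 1 of the 2 values shown sits, records. Within the data shown here, the one measured step, an at least 4.1-fold lower number from compound 1 to compound 2 (0.61 log units; beyond the scatter), is the only guide to how this position behaves: lengthening the chain on the oxygen toward a benzyl group lowered the number beyond the scatter.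

Compound 3 `CCC1(Cc2ccccc2)OS(=O)(=O)C=C1OCc1ccccc1` differs from compound 2 by phenyl in place of benzyl on a saturated chain carbon bound to an oxygen on an unsaturated carbon, so it sits between compound 1 and compound 2 in chain length at that place. Among the measured compounds shown here, no measured step covers this exact change, and the single step on record, from hydrogen to benzyl, does not tell whether the aromatic ring or the chain length carried the effect. The expected shift is therefore small, a step of about a 1.5-fold higher number from compound 2 to compound 3 (0.16 log units; within the scatter) in this assay, with the direction uncertain. Compound 3 is expected to give roughly 70000 nM, plausibly between 30000 nM and 200000 nM.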

Compound 3, half-maximal cytotoxic concentration: 200000 nM
For compound 3 the middle estimate is 2.9-fold (0.46 log units) below the measured one; measured number inside the range.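

In this assay, exchanging phenethyl for benzyl on the oxygen gives a 4.2-fold higher number from compound 2 to compound 3 (0.62 log units; beyond the scatter), and since the two compounds carry the same six-membered aromatic ring of carbon only, the presence of that ring does not by itself set the number; the earlier step from hydrogen to benzyl could not separate the ring from the length of the chain, whereas this pair shows that the chain length at this place matters on its own. Compound 1 gives > 200000 nM, which is a limit of the assay and not a number. The step that compares the shared core with and without the aromatic ring on this shorter chain is a number no higher from compound 1 to compound 3 (the limit leaves the size open) and therefore cannot be read for size, so whether the ring has any effect at this chain length stays unknown: the limit of > 200000 nM in this assay, at which 1 of the 3 values shown sits.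

This trend rests on a single pair, so it is unclear whether a longer chain, such as phenylpropyl, would lower the number further. From the compounds shown here alone, it is equally open how an amine or a carboxylic acid on the aromatic ring would read in this assay.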